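Benzylpiperazine variation on a shared bicyclic lactam core

The source may hold more compounds than are shown below. What is called first, only, known or untested is meant among the compounds shown, and "the series" means these compounds.

Measured so far:
compound 1: `COC(=O)C1=CN(C(C)C)C(=O)[C@@H]2C(CN3CCN(Cc4ccc([N+](=O)[O-])cc4)CC3)=CC[C@H]12` — 87.6%
compound 2: `COC(=O)C1=CN(C)C(=O)[C@@H]2C(CN3CCN(Cc4cccc(C(F)(F)F)c4)CC3)=CC[C@H]12` — 80.3%

In a functional assay on Cortical neurone cells (Rattus norvegicus, strain Sprague-Dawley), read by MTT assay, with stated times of 24 h and 2 h, tested at 10 uM (a lower number here means a weaker effect, a higher number a stronger effect of the compound at the concentration tested), compound 1 gives 87.6%, the higher of the two numbers shown. Compound 2 gives 80.3%, which lies within the scatter of compound 1, so no order between the two is claimed. Compound 3 `COC(=O)C1=CN(C(C)C)C(=O)[C@@H]2C(CN3CCN(Cc4cccc(OC)c4)CC3)=CC[C@H]12` differs from compound 1 by 3-methoxyphenyl in place of 4-nitrophenyl on a saturated chain carbon bound to an amine nitrogen in a ring. Going by the values given here, no step between measured compounds with a single change is available, and compound 2 differs from compound 1 in more than one place, so nothing measured isolates this change. The step of a number 5.6 percentage points lower from compound 1 to compound 3 (within the scatter) is expected to be small, not beyond the scatter. Compound 3 is estimated at 82%, within 65% to 95%.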

Compound 3, a percentage reported as activity, at one concentration (the size of the read-out at that concentration, not a potency): 64%
Compound 3: middle estimate off by 18 percentage points, on the high side; measured number below the stated range.
By their numbers in this assay, from the lowest: compound 3; then compounds 2 and 1 (each within the scatter of the next).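

Going by these compounds alone, the aryl group on a saturated chain carbon bound to an amine nitrogen in a ring is not a silent place on the core of compound 1: in this assay, 3-methoxyphenyl in place of 4-nitrophenyl gives a number 23.6 percentage points lower from compound 1 to compound 3 (beyond the scatter) and thus the first single-place change to be read. No measurement at hand bears on the origin of this step.

As far as these compounds go, the change swaps the substituent and its place on the ring together, so which of the two carries the step stays open. A 4-methoxyphenyl or 3-nitrophenyl group on the same carbon would separate them.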